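Ethoxy for butylamino on a shared purine-like core

The compounds below may be only part of what the source reports. "The series", "measured", "known", "first", "only" and "open" are said of these compounds alone.

Compound 1 `CCCOc1nc(N)nc2c1ncn2/C=C1/CC1(CO)CO` in an ADME assay on HFF cells (Homo sapiens) for cytotoxicity, with a stated time of 8 days; on this read-out higher numbers stand for lower toxicity in this test and lower numbers for higher toxicity in this test: > 300000 nM, which is a limit of the assay, not a measured number.
Compound 2 `CCCCNc1nc(N)nc2c1ncn2/C=C1/CC1(CO)CO`: > 300000 nM, again a limit of the assay.
Compound 3 `Nc1nc2c(ncn2/C=C2/CC2(CO)CO)c(=O)[nH]1`: > 300000 nM, again a limit of the assay.

Compound 2 therefore stands only at a limit, with no number of its own, and the two other values shown stand at the same limit (the limit of > 300000 nM in this assay, at which 3 of the 3 values shown sit). Compound 4 `CCOc1nc(N)nc2c1ncn2/C=C1/CC1(CO)CO` differs from compound 2 in a single place: ethoxy in place of butylamino on an aromatic carbon. Among the measured compounds shown here, only one measured step touches this position on the core, a step that the two limits leave unreadable from compound 1 to compound 2; both of its ends are limits, so its size cannot be read. Nothing measured here says whether ethoxy in place of butylamino moves the read-out, and no difference beyond the usual scatter has appeared among the three compounds tested. The expectation for compound 4 is that it also sits at the limit, the step that the limit leaves unreadable from compound 2 to compound 4 being expected to show no change that can be told apart from scatter. The estimate for compound 4 in this assay is 400000 nM, expected to fall between 150000 nM and 1500000 nM.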

Compound 4, half-maximal cytotoxic concentration: > 300000 nM
Compound 4 gave a limit, no number (the forecaster's own chance of this, stated with the estimate: 85%); the middle value lies beyond the limit too.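

Compound 1, compound 2 and compound 4 all sit at a limit of the assay and give no number of their own, so the steps among them cannot be read: the limit of > 300000 nM in this assay, at which 4 of the 4 values shown sit. The compounds shown leave open whether propoxy, butylamino and ethoxy on the shared core differ at all in this assay.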